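This account rests on a few compounds, and the source may have more. Where it says the series, first, only, none or still open, it means among the compounds named here.

For the measured compounds named here, in a functional assay on MDA-MB-231 cells (Homo sapiens) for antiproliferative activity, read by MTT assay, with a stated time of 24 h (on this read-out higher numbers stand for weaker inhibition and lower numbers for stronger inhibition), compound 1 (`O=C(c1cc(Cl)ccn1)N1CCN(c2nccc(Oc3cc(Cl)cc(Cl)c3)n2)CC1`) gives 16700 nM and compound 2 (`O=S(=O)(c1cccnc1)N1CCN(c2nccc(Oc3cc(Cl)cc(Cl)c3)n2)CC1`) gives 24800 nM with the two values inside the scatter of each other, so compound 2 holds no separate place on the numbers so far. Compound 3 (`O=C(Nc1ccccc1Cl)N1CCN(c2nccc(Oc3cc(Cl)cc(Cl)c3)n2)CC1`) has (2-chlorophenyl)carbamoyl in place of (pyridin-3-yl)sulfonyl on an amine nitrogen in a ring. Going by the values given here, the one measured step at that nitrogen (a 1.5-fold higher number from compound 1 to compound 2 (0.17 log units; within the scatter)) stayed within the scatter, so no step beyond the scatter is expected, though a single step is thin support. The estimated step also lies within the scatter (a 1.4-fold lower number from compound 2 to compound 3 (0.14 log units; within the scatter)). In this assay compound 3 is expected at 18000 nM with an estimated range from 7000 nM to 45000 nM for now.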

Compound 3, half-maximal inhibitory concentration: 11000 nM
For compound 3 the middle estimate is 1.6-fold (0.21 log units) above the measured one, and the stated range covers the measured number.
By their numbers in this assay, from the lowest: compounds 3, 1 and 2 (each within the scatter of the next, the first and the last beyond it).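

In this assay, for the compounds shown here, (2-chlorophenyl)carbamoyl on the amine nitrogen in the ring gives the first step beyond the scatter at this position, a modest one: a 2.3-fold lower number from compound 2 to compound 3 (0.35 log units; beyond the scatter). Replacing 4-chloropyridin-2-yl on the carbonyl carbon with (2-chlorophenyl)amino stays within the scatter, a 1.5-fold lower number from compound 1 to compound 3 (0.18 log units; within the scatter), so the urea of compound 3 is not separated from the amide of compound 1. No evidence bears on the reason for either step.

Open, as far as these compounds go, is how an acetyl or an unsubstituted phenylcarbamoyl group would read on that nitrogen. From the compounds shown here alone, the shared core stays constant across all three compounds, so its contribution remains untested.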